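Compound 4 as a Methoxy Variant of a Limited Series

The source may report more compounds than this note shows. Statements on the series, on what has been measured and on what is new or still open speak of the compounds shown alone.

Compound 1 `Cc1ccc(N2CCN(CC(=O)N(c3ccccc3)c3ccccc3)CC2)cc1` was tested in a functional assay on the whole organism (strain Swiss albino) for inhibition, with Mus musculus as the target, with stated times of 10 min, 5 min and 20 min; a higher number here means that more compound is needed for the effect, a lower number that less compound is needed. In this assay compound 1 gives only a limit, > 20 mg/kg, and no number. Two companions differ from it only in the aryl group on the ring nitrogen: compound 2 `Cc1cccc(N2CCN(CC(=O)N(c3ccccc3)c3ccccc3)CC2)c1C` gives 28.5 mg/kg in this assay, and compound 3 `O=C(CN1CCN(c2cccc(C(F)(F)F)c2)CC1)N(c1ccccc1)c1ccccc1` gives 21.3 mg/kg. Compound 1 thus stands at the limit of > 20 mg/kg in this assay, at which 1 of the 3 values shown sits, and its place relative to the other two cannot be fixed.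

Compound 4 `COc1cccc(N2CCN(CC(=O)N(c3ccccc3)c3ccccc3)CC2)c1` differs from compound 1 by 3-methoxyphenyl in place of 4-methylphenyl on an amine nitrogen in a ring. Among the compounds with values here, the measured steps that bear on this change are a step that the limit leaves unreadable from compound 1 to compound 2 and a step that the limit leaves unreadable from compound 1 to compound 3, neither of which can be sized, while the one readable step, a 1.3-fold lower number from compound 2 to compound 3 (0.13 log units; within the scatter), stays within the scatter. Nothing in the data separates the three aryl groups by more than the scatter, so one expects no step beyond the scatter in this assay from compound 1 to compound 4. Compound 4 is therefore estimated at 25 mg/kg, between 14 mg/kg and 45 mg/kg. The estimate for compound 4 means an expected step that the limit leaves unreadable from compound 1 to compound 4.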

Compound 4, dose for half-maximal effect: 10 mg/kg
Compound 4: the middle estimate sits 2.5-fold (0.40 log units) above what was measured; measured number below the stated range.
By their numbers in this assay, from the lowest: compound 4; then compounds 3 and 2 (each within the scatter of the next).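

Within this assay, the aryl group on the ring nitrogen now produces steps beyond the scatter, which the earlier readable comparison did not: methoxy in place of trifluoromethyl on an aromatic carbon gives a 2.1-fold lower number from compound 3 to compound 4 (0.33 log units; beyond the scatter), and 3-methoxyphenyl in place of 2,3-dimethylphenyl gives a 2.9-fold lower number from compound 2 to compound 4 (0.45 log units; beyond the scatter). Against the 4-methylphenyl group, the change gives an at least 2.0-fold lower number from compound 1 to compound 4 (0.30 log units; that floor lies within the scatter), so this comparison alone does not show a real separation between those two aryl groups. Compound 1 remains a limit and not a number: the limit of > 20 mg/kg in this assay, at which 1 of the 4 values shown sits.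

The compounds shown leave open whether the lower number follows from the methoxy group itself, as a hydroxy or ethoxy group on the same aromatic carbon would help to show. They also leave open how an unsubstituted phenyl group on the ring nitrogen would compare, and where compound 1 would fall if it had a number.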